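Bromo-to-methyl exchange in a thiosemicarbazone isatin series

The compounds below may be only part of what the source reports. "The series", "measured", "known", "first", "only" and "open" are said of these compounds alone.

Three members of the series have been measured in a functional assay on COS-7 cells (Chlorocebus aethiops) for inhibition, read by MTT assay (a higher number here means a weaker inhibitor, a lower number a stronger inhibitor), and none gives a number. Compound 1 `O=C1Nc2ccc(Br)cc2/C1=N/NC(=S)N/N=C/c1ccccc1Br` reaches only the assay limit, > 50000 nM. Compound 2 `Cc1ccc2c(c1)/C(=N/NC(=S)N/N=C/c1ccccc1Br)C(=O)N2` likewise stops at the limit, > 50000 nM. Compound 3 `COc1ccc(/C=N/NC(=S)N/N=C2\C(=O)Nc3ccc(Br)cc32)c(OC)c1` is also reported as a limit, > 50000 nM. The difference between compound 1 and compound 2 is methyl in place of bromo on an aromatic carbon, and the step that the two limits leave unreadable from compound 1 to compound 2 cannot be read, because of the limit of > 50000 nM in this assay, at which 3 of the 3 values shown sit.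

Compound 4 `COc1ccc(/C=N/NC(=S)N/N=C2\C(=O)Nc3ccc(C)cc32)c(OC)c1` is not yet measured in this assay. It differs from compound 3 by methyl in place of bromo on an aromatic carbon, the same change as that from compound 1 to compound 2. The difference between the two cores, that of compound 1 and that of compound 3, is not broken down here.

For compound 4 the step that the limit leaves unreadable from compound 3 to compound 4 is expected to be unreadable as well, since it rests only on the unreadable step from compound 1 to compound 2 and on the limit of compound 3. Compound 4 is therefore estimated at 100000 nM, most likely again reported as a limit.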

Compound 4, half-maximal inhibitory concentration: > 50000 nM
Compound 4 gave a limit, no number; the forecaster's own chance of this, stated with the estimate: 85%; the middle value lies beyond the limit too.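

No new step can be read from compound 3 to compound 4, because both compounds stop at a limit and give no number: the limit of > 50000 nM in this assay, at which 4 of the 4 values shown sit.

Still open is whether methyl in place of bromo on an aromatic carbon changes inhibition at all in this assay and whether any compound shown in this series reaches a measurable value.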